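Swapping the anilino ring substituent: from methyl to hydroxyl

The compounds below may be only part of what the source reports. "The series", "measured", "known", "first", "only" and "open" are said of these compounds alone.

Measured compounds:
Compound 1, `CC(C)c1ccc(-c2nc(SCc3cn(CC(=O)NC(=O)Nc4ccccn4)nn3)nc(Nc3cccc(C(F)(F)F)c3)c2C#N)cc1`, gives 8620 nM in a functional assay on MCF7 cells (Homo sapiens) for inhibition, read by MTT assay, with a stated time of 72 h; on this read-out higher numbers stand for weaker inhibition and lower numbers for stronger inhibition.
Compound 2, `Cc1ccccc1Nc1nc(SCc2cn(CC(=O)NC(=O)Nc3ccccn3)nn2)nc(-c2ccc(C(C)C)cc2)c1C#N`, reaches only the assay limit of > 64000 nM in this assay.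
Compound 3, `Cc1cccc(Nc2nc(SCc3cn(CC(=O)NC(=O)Nc4ccccn4)nn3)nc(-c3ccc(C(C)C)cc3)c2C#N)c1`, likewise reaches only the limit of > 64000 nM in this assay.

Compound 3 thus stands at a limit, not at a number, as does one further value here (the limit of > 64000 nM in this assay, at which 2 of the 3 values shown sit). Compound 4, `CC(C)c1ccc(-c2nc(SCc3cn(CC(=O)NC(=O)Nc4ccccn4)nn3)nc(Nc3ccccc3O)c2C#N)cc1`, differs from it by 2-hydroxyphenyl in place of 3-methylphenyl on a nitrogen on an aromatic ring. For the measured compounds named here, no measured step involves a hydroxyl. The nearest steps are an at least 7.4-fold higher number from compound 1 to compound 3 (0.87 log units; beyond the scatter) and an at least 7.4-fold higher number from compound 1 to compound 2 (0.87 log units; beyond the scatter), while a step that the two limits leave unreadable from compound 2 to compound 3. A limit as a starting point and no related change leave the direction open; compound 4 is expected to stay weak, at 45000 nM, within 8000 nM to 150000 nM. For compound 4 this means an expected step of an at least 1.4-fold lower number from compound 3 to compound 4 (0.15 log units; that floor lies within the scatter).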

Compound 4, half-maximal inhibitory concentration: > 64000 nM
Compound 4: no number, only a limit; the forecaster's own chance of this, stated with the estimate: 55%; middle value at least 1.4-fold (0.15 log units) from the limit.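

In this assay, compound 4 also stands only at a limit, so the 2-hydroxyphenyl group, with its hydrogen-bond donor, gives no measurable value on this nitrogen. The one readable result is an at least 7.4-fold higher number from compound 1 to compound 4 (0.87 log units; beyond the scatter). Three different replacements of 3-(trifluoromethyl)phenyl now end the same way, and the steps among compounds 2, 3 and 4 cannot be read: the limit of > 64000 nM in this assay, at which 3 of the 4 values shown sit.

The compounds shown leave the order of compounds 2, 3 and 4 open. Also open, as far as these compounds go, is whether a phenyl ring carrying an amine or a carboxylic acid would give a measurable value here.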